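This account rests on a few compounds, and the source may have more. Where it says the series, first, only, none or still open, it means among the compounds named here.

Compound 1 `C=CCNC(=O)/C(C)=C(/C)c1ccc(Cl)cc1` gives 400 mg/kg in a toxicity assay on the whole organism (strain Icem-CET (SPF Caw)) for cytotoxicity, with Mus musculus as the target; on this read-out lower numbers stand for an effect already at smaller amounts and higher numbers for an effect only at larger amounts of compound. Compound 2 `C=CCNC(=O)/C(C)=C(/C)c1ccccc1` gives 400 mg/kg in this assay. The change from compound 1 to compound 2 is hydrogen in place of chloro on an aromatic carbon, and the step it made was no change at the digits printed from compound 1 to compound 2 (within the scatter). Compound 3 `C#CCNC(=O)/C(C)=C(\C)c1ccc(Cl)cc1` gives 200 mg/kg in this assay. The difference between the core of compound 3 and the core of compound 1 is not broken down here. Compound 4 `C#CCNC(=O)/C(C)=C(\C)c1ccccc1` has not been measured in this assay; it differs from compound 3 by hydrogen in place of chloro on an aromatic carbon, the same change, at the same place, as from compound 1 to compound 2. A step of the same size is expected, no change at the digits printed from compound 3 to compound 4 (within the scatter), because the earlier step of no change at the digits printed from compound 1 to compound 2 (within the scatter) stayed within the scatter. Compound 4 is therefore estimated at 200 mg/kg, with a range from 120 mg/kg to 350 mg/kg.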

Compound 4, dose for half-maximal effect: 150 mg/kg
Estimate against measurement, compound 4: 1.3-fold (0.12 log units) above; the measured number falls inside the stated range.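

Hydrogen in place of chloro on an aromatic carbon gives a 1.3-fold lower number from compound 3 to compound 4 (0.12 log units; within the scatter) in this assay. The change carries across the two cores with no difference that stands out from the scatter: the same change on two cores in this assay, no change at the digits printed (within the scatter) from compound 1 to compound 2 and a 1.3-fold lower number (0.12 log units; within the scatter) from compound 3 to compound 4, 1.3-fold (0.12 log units) apart, within the scatter of two such steps. This shows that on these two cores the chloro can be exchanged for hydrogen without a step beyond the scatter, but it does not show that the step is exactly zero or that the same holds on any third core.

The compounds shown leave open other groups at the same place, such as bromo, methoxy or an amine. Among the compounds shown here, they also hold no pair that differs only in the chain on the amide nitrogen, so the difference between the two cores stays unresolved.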